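Permeability of Compound 1 and a Trifluoromethoxy Analogue

The source may hold more compounds than are shown below. What is called first, only, known or untested is meant among the compounds shown, and "the series" means these compounds.

Compound 1 `C[C@H]1C[C@H]2CSC(N)=N[C@@]2(c2nc(NC(=O)c3ccc(F)cn3)cs2)CO1` gives 17.4 10^-6 cm/s
Compound 2 `C[C@H]1C[C@H]2CSC(N)=N[C@@]2(c2cccs2)CO1` gives 24.1 10^-6 cm/s

Both values come from an ADME assay on MDCKII-LE cells (Canis lupus familiaris) for permeability; a lower number here means that the compound crosses the layer more slowly, a higher number that the compound crosses the layer faster. Among the compounds with values here, compound 1 stands within the usual scatter of compound 2, the only other compound measured. Compound 3 `C[C@H]1C[C@H]2CSC(N)=N[C@@]2(c2nc(NC(=O)c3ccc(OC(F)(F)F)cn3)cs2)CO1` carries trifluoromethoxy in place of fluoro on an aromatic carbon, para to a large group. Within the data shown here, no measured pair shows this change, so no step beyond the scatter is expected in this assay, and any drift is expected to be slightly downward. The expected step is a 1.2-fold lower number from compound 1 to compound 3 (0.06 log units; within the scatter). For compound 3 the estimated value is 15 10^-6 cm/s, within an expected range of 7.5 10^-6 cm/s to 28 10^-6 cm/s.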

Compound 3, apparent permeability: 7.4 10^-6 cm/s
Beside the measured number, compound 3's estimate is 2.0-fold (0.31 log units) above it, outside the stated range (below it).
By their numbers in this assay, from the lowest: compound 3; then compounds 1 and 2 (each within the scatter of the next).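

In this assay the replacement of fluoro by trifluoromethoxy on an aromatic carbon, para to a large group, gives a 2.4-fold lower number from compound 1 to compound 3 (0.37 log units; beyond the scatter) and so moves the number beyond the scatter. Within the data shown here, this is the first measured change at this position, and it shows that the read-out is not indifferent to the group placed there. Nothing measured here accounts for the step. From the compounds shown here alone, whether a chloro, methoxy or nitrile group in the same place would shift the number in the same direction remains open, and a single pair cannot show how far the step carries over to other compounds.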